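From a Ring on Sulfur to a Ring on Carbon

This account rests on a few compounds, and the source may have more. Where it says the series, first, only, none or still open, it means among the compounds named here.

Within the data shown here, compound 2 `CC(C(=O)NCc1ccc(C(F)(F)F)cc1SC1CCCCC1)c1ccc(NS(C)(=O)=O)c(F)c1` holds the lower of the two numbers measured so far in an assay on CHO cells for antagonist activity at transient receptor potential cation channel subfamily V member 1 (Homo sapiens), read by FLIPR (a higher number here means a weaker inhibitor, a lower number a stronger inhibitor), where compound 2 gives 0.5 nM. Among the measured compounds shown here, its only measured neighbour is compound 1 `CCCCSc1cc(C(F)(F)F)ccc1CNC(=O)C(C)c1ccc(NS(C)(=O)=O)c(F)c1`, which in this assay gives 1.9 nM; the step of a 3.8-fold lower number from compound 1 to compound 2 (0.58 log units; beyond the scatter) is the single comparison available and shows that what hangs on the sulfur can shift the number by a modest amount. Compound 3 `CC(C(=O)NCc1ccc(C(F)(F)F)cc1-c1cccc(Cl)c1)c1ccc(NS(C)(=O)=O)c(F)c1` alters that same part of the molecule once more: 3-chlorophenyl in place of cyclohexylsulfanyl on an aromatic carbon. For the measured compounds named here, no measured step covers a swap of this kind, so the size of the coming step can only be guessed from the one known change there having been modest. The expectation for compound 3 is a step of a 3.0-fold higher number from compound 2 to compound 3 (0.48 log units; beyond the scatter), most likely within the scatter or a small loss. Compound 3 is therefore estimated at 1.5 nM, with a range from 0.3 nM to 8 nM.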

Compound 3, inhibition constant: 1 nM
The estimate for compound 3 lay 1.5-fold (0.18 log units) above the measured number, within the range that was stated.
By their numbers in this assay, from the lowest: compounds 2, 3 and 1 (each within the scatter of the next, the first and the last beyond it).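

In this assay the sulfur link turns out not to be required at this aromatic carbon: a ring bonded directly in its place gives a 2.0-fold higher number from compound 2 to compound 3 (0.30 log units; within the scatter) and, set against the open butyl chain, a 1.9-fold lower number from compound 1 to compound 3 (0.28 log units; within the scatter) as well. The position, ortho to a large group and meta to a trifluoromethyl group, therefore accepts a flat aromatic 3-chlorophenyl as well as the non-aromatic cyclohexylsulfanyl and the chain-like butylsulfanyl, with compound 3 lying within the scatter of both sulfur compounds. No supporting measurement bears on why these groups read so closely.

As far as these compounds go, whether the chlorine matters stays open, as does how a plain phenyl, a pyridyl or a phenoxy group would read at this carbon. Also open, from the compounds shown here alone, is whether the result would hold with a nitrile in place of the trifluoromethyl group.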